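A Nitrophenyl Traded for a Methoxyphenyl: Compound 3

The source may report more compounds than this note shows. Statements on the series, on what has been measured and on what is new or still open speak of the compounds shown alone.

Of the compounds shown here, two have so far been tested in a functional assay on the whole organism (strain Wistar) with Rattus norvegicus as the target, with a stated time of 15 days, at a dose of 3 mg/kg by the oral route; a higher number here means a stronger effect of the compound at the dose given, a lower number a weaker effect. Compound 1 `O=C1NC(=O)/C(=C/c2ccc(OCCSc3nnc(-c4ccc([N+](=O)[O-])cc4)[nH]3)cc2)S1` gives 14.1%. Compound 2 `O=C1NC(=O)/C(=C/c2ccc(OCCSc3nnc(-c4ccccc4[N+](=O)[O-])[nH]3)cc2)S1` carries a 2-nitrophenyl in place of the 4-nitrophenyl of compound 1; in this assay compound 2 gives 19.8%. Compound 2 thus holds the higher of the two numbers, but the step of a number 5.7 percentage points higher from compound 1 to compound 2 (within the scatter) lies within the usual scatter, so the two compounds cannot be told apart on this evidence.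

Compound 3 `COc1ccc(-c2nnc(SCCOc3ccc(/C=C4\SC(=O)NC4=O)cc3)[nH]2)cc1` has not yet been measured. It differs from compound 2 in one place: 4-methoxyphenyl in place of 2-nitrophenyl on an aromatic carbon. Among the compounds with values here, the only measured step that touches the same position is the one from compound 1 to compound 2, which exchanged one nitrophenyl for another and produced a change within the scatter. That step suggests the group at this position has had little influence so far, although a methoxyphenyl has not been tried. The expectation for compound 3 in this assay is therefore a step of about a number 2.8 percentage points lower from compound 2 to compound 3 (within the scatter), which stays within the scatter. Compound 3 is thus estimated to give 17%, with a plausible range from 5% to 32%.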

Compound 3, a percentage reported as activity, at one dose (the size of the read-out at that dose, not a potency): 43.1%
Estimate against measurement, compound 3: 26.1 percentage points below, and the stated range ends below it.
By their numbers in this assay, from the lowest: compounds 1 and 2 (each within the scatter of the next); then compound 3.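

In this assay, the group on the aromatic carbon between two ring nitrogen atoms now clearly matters: 4-methoxyphenyl in place of 2-nitrophenyl gives a number 23.3 percentage points higher from compound 2 to compound 3 (beyond the scatter), and methoxy in place of nitro on the same phenyl carbon gives a number 29 percentage points higher from compound 1 to compound 3 (beyond the scatter). Within the data shown here, the earlier exchange of one nitrophenyl for another could not be told from scatter, so the flat picture at this position held only among nitrophenyl groups, and the first step beyond the scatter comes when the nitro group is gone and a methoxy stands in its place. Nothing available here accounts for this rise.

The compounds shown cannot say whether the gain depends on the methoxy group itself or simply on the absence of nitro, and a plain phenyl, a 4-ethoxyphenyl or a 4-aminophenyl at this position would help to separate those two readings. They also leave open whether a 2-methoxyphenyl would match the 4-methoxyphenyl, and, with only one dose tested, how the compounds would compare at other doses.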